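The compounds below may be only part of what the source reports. "The series", "measured", "known", "first", "only" and "open" are said of these compounds alone.

Compound 1 `C=C1CCCC(C)(C)C1CC[C@]1(C)CC[C@@H]([C@@H](C)C(=O)O)OO1` and compound 2 `C=C1CCCC(C)(C)C1CC[C@]1(C)CC[C@H]([C@@H](C)C(=O)OC)OO1` carry the smaller core. In a functional assay on A498 cells (Homo sapiens) for inhibition (on this read-out lower numbers stand for stronger inhibition of growth and higher numbers for weaker inhibition of growth), compound 1 gives > 10000 nM, which is a limit of the assay and not a number, namely (the limit of > 10000 nM in this assay, at which 1 of the 3 values shown sits). Compound 2 gives 4920 nM in this assay. Compound 3 `C=C1CCC[C@H]2[C@](C)(CC[C@]3(C)CC[C@@H]([C@@H](C)C(=O)O)OO3)[C@@H](C)CC[C@]12C` gives 1590 nM in this assay, the lowest of the two numbers, with compound 2 next at a larger number beyond the scatter. Compound 4 `C=C1CCC[C@H]2[C@](C)(CC[C@]3(C)CC[C@H]([C@@H](C)C(=O)O)OO3)[C@@H](C)CC[C@]12C` is not yet measured; set against compound 3, (the two compounds have the same atoms and bonds and differ only in configuration as drawn: 1 of 7 stereo elements differ; a stereocentre at a saturated ring carbon is drawn S in compound 3 and R in compound 4). Among the measured compounds shown here, no measured pair turns on this change alone, so the expected step of a 1.9-fold higher number from compound 3 to compound 4 (0.28 log units; within the scatter) is taken as a moderate loss, near the edge of the scatter. For compound 4 the estimate in this assay is 3000 nM, ranging from 800 nM to 15000 nM.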

Compound 4, concentration for 50% growth inhibition: 1930 nM
Estimate against measurement, compound 4: 1.6-fold (0.19 log units) above; the measured number falls inside the stated range.
By their numbers in this assay, from the lowest: compounds 3 and 4 (each within the scatter of the next); then compound 2. At a limit, above all of these: compound 1.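

In this assay, the change of this saturated ring carbon from S to R gives a 1.2-fold higher number from compound 3 to compound 4 (0.08 log units; within the scatter), so on the larger core the drawn configuration here leaves the growth-inhibition read-out unchanged within the scatter. Compound 1 and compound 2 differ in more than this stereocentre and could not show this. The reading is clean for one reason: the fact that compounds 3 and 4 differ only in the configuration as drawn

Among the compounds shown here, whether the smaller core tolerates the same change stays open, since no pair there turns on configuration alone. Also open, from the compounds shown here alone, is how a primary amide in place of the carboxylic acid would read at either configuration.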